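A few compounds are considered here, and "the series" means these few. Any claim that something is new, unique, unknown or untested is made for them only; others in the source may bear on it.

Measured compounds in a functional assay on PC-3 cells (Homo sapiens) for antiproliferative activity, read by MTT assay, with a stated time of 48 h; a higher number here means a weaker inhibitor, a lower number a stronger inhibitor:

compound 1, `NS(=O)(=O)c1ccc(Nc2ncc(F)c(Nc3nc4ccc(Cl)cc4s3)n2)cc1`: 1430 nM
compound 2, `COc1ccc(Nc2ncc(C)c(Nc3nc4ccccc4s3)n2)cc1`: > 50000 nM

For the measured compounds named here, compound 1 carries the only numerical value in this assay, at 1430 nM. The value for compound 2 is a limit of the assay rather than a number, (the limit of > 50000 nM in this assay, at which 1 of the 2 values shown sits), so compound 2 sets no scale against which compound 1 can be ranked beyond saying that compound 1 gives a measurable result and compound 2 does not. Going by the values given here, compound 2 differs from compound 1 in more than one place, so the two values give no single step to learn from.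

The unmeasured compound 3, `COc1ccc2nc(Nc3nc(Nc4ccc(S(N)(=O)=O)cc4)ncc3F)sc2c1`, departs from compound 1 in one place only: methoxy in place of chloro on an aromatic carbon. Among the compounds with values here, no measured pair in this set isolates this kind of change, so there is no step to lean on. For this assay the expectation is a small step from compound 1 to compound 3, most likely towards a weaker inhibitor, but one that could well stay within the scatter: the step from compound 1 to compound 3 is estimated at a 1.7-fold higher number from compound 1 to compound 3 (0.24 log units; within the scatter). Compound 3 is therefore estimated at 2500 nM, with a range from 800 nM to 8000 nM.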

Compound 3, half-maximal inhibitory concentration: > 50000 nM
Compound 3: no number, only a limit; the forecaster's own chance of this, stated with the estimate: 10%; middle value at least 20-fold (1.30 log units) away from the limit.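

In this assay, methoxy in place of chloro on an aromatic carbon of the fused two-ring system gives an at least 34-fold higher number from compound 1 to compound 3 (1.54 log units; beyond the scatter). For the compounds shown here, this is the first single-place change, and it shows that this position is not indifferent: with the rest of the structure held fixed, this one exchange is enough to leave no measurable value in this assay. The step gives only a minimum size and the full gap stays unknown, because the value for compound 3 is a limit and not a number: the limit of > 50000 nM in this assay, at which 2 of the 3 values shown sit.

The compounds shown do not separate the loss of chloro from the entry of methoxy, a question that a bromo, ethyl or amino group on the same aromatic carbon would help to settle. They also leave open whether methoxy would have the same outcome on another carbon of that ring, or whether the outcome depends on the sulfonamide-bearing part of the core of compound 1.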